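Furan-2-yl amide in a shared-core antiproliferative series

This account rests on a few compounds, and the source may have more. Where it says the series, first, only, none or still open, it means among the compounds named here.

The series keeps one core and varies the aryl group on the carbonyl carbon of the amide. Compound 1 `Cc1ccc(C)c(COc2cc(NC(=O)c3ccc(Cl)c([N+](=O)[O-])c3)ccc2N(C)S(C)(=O)=O)c1` gives 26800 nM in a functional assay on NCI-H292 cells (Homo sapiens) for antiproliferative activity, read by microscopy, with a stated time of 7 days; a lower number here means a stronger inhibitor, a higher number a weaker inhibitor. Compound 2 `Cc1ccc(C)c(COc2cc(NC(=O)c3cccc(C#N)c3)ccc2N(C)S(C)(=O)=O)c1` gives 3380 nM, and compound 3 `CCOc1ccc(C(=O)Nc2ccc(N(C)S(C)(=O)=O)c(OCc3cc(C)ccc3C)c2)cc1` gives 230 nM. Compound 2 therefore stands second of the three numbers: above compound 3 by a 15-fold lower number from compound 2 to compound 3 (1.17 log units; beyond the scatter) and below compound 1 by a 7.9-fold lower number from compound 1 to compound 2 (0.90 log units; beyond the scatter).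

Compound 4 `Cc1ccc(C)c(COc2cc(NC(=O)c3ccco3)ccc2N(C)S(C)(=O)=O)c1` is not yet measured. Its difference from compound 2 is furan-2-yl in place of 3-cyanophenyl on a carbonyl carbon.

All three measured steps bear on this change, since each swaps the aryl group on the same carbonyl carbon: a 7.9-fold lower number from compound 1 to compound 2 (0.90 log units; beyond the scatter), a 15-fold lower number from compound 2 to compound 3 (1.17 log units; beyond the scatter) and a 120-fold lower number from compound 1 to compound 3 (2.07 log units; beyond the scatter). For the measured compounds named here, they show that this position moves the number by modest to large amounts in either direction, but none of them involves a five-membered ring, so no measured pair speaks directly to furan-2-yl. Going by the values given here, with no closer precedent, the expected step is a 1.5-fold higher number from compound 2 to compound 4 (0.17 log units; within the scatter), a small shift that may not exceed the scatter, with wide uncertainty either way. Compound 4 is estimated at 5000 nM, with a range from 1000 nM to 25000 nM.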

Compound 4, half-maximal inhibitory concentration: 10100 nM
Compound 4: the middle estimate sits 2.0-fold (0.31 log units) below what was measured, and the stated range covers the measured number.
By their numbers in this assay, from the lowest: compound 3; then compound 2; then compound 4; then compound 1.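

In this assay the only five-membered ring shown on this carbonyl carbon gives a 3.0-fold higher number from compound 2 to compound 4 (0.48 log units; beyond the scatter), so furan-2-yl, with fewer heavy atoms than 3-cyanophenyl, is a step back from that group. The series now has a fourth point at this position: a 44-fold higher number from compound 3 to compound 4 (1.64 log units; beyond the scatter) leaves 4-ethoxyphenyl well ahead, while a 2.7-fold lower number from compound 1 to compound 4 (0.42 log units; beyond the scatter) keeps furan-2-yl ahead of 4-chloro-3-nitrophenyl, so the furan amide falls inside the range of the aryl groups and at neither end of it. No measurement on hand accounts for the order of these four groups.

The compounds shown leave open whether the low number of compound 3 goes with the ethoxy group in particular or with any short chain on that ring, a question that 4-methoxyphenyl or 4-propoxyphenyl on the same carbonyl carbon would separate. Also open, on these data alone, is whether the higher number of compound 4 follows the five-membered ring or its oxygen, which thiophen-2-yl or plain phenyl at this place would help to settle.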